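The source may report more compounds than this note shows. Statements on the series, on what has been measured and on what is new or still open speak of the compounds shown alone.

Compound 1 `Cc1ccc(C(=O)Nc2cc(-n3ccnc3)cc(C(F)(F)F)c2)cc1Nc1nc(-c2cccnc2)cs1` gives 36 nM in a functional assay on KU812 cells (Homo sapiens) for antiproliferative activity; on this read-out higher numbers stand for weaker inhibition and lower numbers for stronger inhibition. Compound 2 `Cc1ncn(-c2cc(NC(=O)c3ccc(C)c(Nc4nc(-c5cccnc5)cs4)c3)cc(C(F)(F)F)c2)n1` gives 38 nM in this assay, and the change from compound 1 to compound 2 a 1.1-fold higher number from compound 1 to compound 2 (0.02 log units; within the scatter) lies within the scatter. Compound 2 stands at the higher of the two numbers, but its gap to compound 1 is within the scatter. Compound 3 `Cc1ccc(C(=O)Nc2cccc(C(F)(F)F)c2)cc1Nc1nc(-c2cccnc2)cs1` differs by hydrogen in place of 3-methyl-1H-1,2,4-triazol-1-yl on an aromatic carbon. Going by the values given here, the one measured step swapped one five-membered aromatic ring for another and did not remove one, so no measured step bears directly on this change. A modest rise in the number is estimated, the expected step being a 2.4-fold higher number from compound 2 to compound 3 (0.37 log units; beyond the scatter). Compound 3 is therefore expected to give 90 nM in this assay, within a range from 25 nM to 350 nM.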

Compound 3, half-maximal inhibitory concentration: 1240 nM
Compound 3: the middle estimate sits 14-fold (1.14 log units) below what was measured, and the stated range ends below it.
By their numbers in this assay, from the lowest: compounds 1 and 2 (each within the scatter of the next); then compound 3.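

Putting hydrogen in place of the five-membered aromatic ring costs far more than exchanging one such ring for the other: in this assay the outcome is a 33-fold higher number from compound 2 to compound 3 (1.51 log units; beyond the scatter) and, starting from the imidazole, a 34-fold higher number from compound 1 to compound 3 (1.54 log units; beyond the scatter). On this aromatic carbon, meta to a trifluoromethyl group, either ring therefore goes with much stronger inhibition than hydrogen. No evidence at hand accounts for the size of this loss.

On these data alone, whether a ring is needed at all stays open. A simple amine or a short alkyl chain on this carbon might or might not restore the inhibition.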